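A few compounds are considered here, and "the series" means these few. Any claim that something is new, unique, unknown or untested is made for them only; others in the source may bear on it.

Compound 3 `COCc1ccc(/C=N/NC(=O)c2ccc(O)c(Cl)c2)c2ccccc12` gives 75.5 nM in an assay on BHK cells for binding affinity to Glucagon receptor (Homo sapiens) (on this read-out higher numbers stand for weaker inhibition and lower numbers for stronger inhibition), within the scatter of compound 2 `O=C(N/N=C/c1ccc(CO)c2ccccc12)c1ccc(O)c(Cl)c1Cl` at 53.8 nM and of compound 1 `O=C(N/N=C/c1ccc(CO)c2ccccc12)c1ccc(O)c(Cl)c1` at 41.1 nM. Compound 4 `CC(C)CS(=O)(=O)c1ccc(/C=N/NC(=O)c2ccc(O)c(Cl)c2)c2ccccc12` carries isobutylsulfonyl in place of methoxymethyl on an aromatic carbon. Among the compounds with values here, the one step at that position, a 1.8-fold higher number from compound 1 to compound 3 (0.26 log units; within the scatter), stayed within the scatter; the other step, a 1.3-fold higher number from compound 1 to compound 2 (0.12 log units; within the scatter), concerns a different ring and bears little here. Since the isobutylsulfonyl adds more heavy atoms than any change yet tested, the expectation for compound 4 is a step of a 1.3-fold higher number from compound 3 to compound 4 (0.10 log units; within the scatter), a small move towards weaker binding that may not exceed the scatter. Compound 4 is therefore estimated at 95 nM in this assay, with a range from 30 nM to 300 nM.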

Compound 4, half-maximal inhibitory concentration: 181 nM
Beside the measured number, compound 4's estimate is 1.9-fold (0.28 log units) below it; the range from low to high includes it.
By their numbers in this assay, from the lowest: compounds 1, 2 and 3 (each within the scatter of the next); then compound 4.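

Isobutylsulfonyl in place of methoxymethyl gives a 2.4-fold higher number from compound 3 to compound 4 (0.38 log units; beyond the scatter) in this assay, the first step at this position to pass beyond the scatter. Isobutylsulfonyl in place of hydroxymethyl gives a 4.4-fold higher number from compound 1 to compound 4 (0.64 log units; beyond the scatter) in this assay, so this aromatic carbon does respond to substitution, though only modestly, and the larger group still binds. Nothing measured here explains the shift.
Going by these compounds, whether the sulfonyl or the isobutyl chain carries the step stays open. Methylsulfonyl, a sulfonamide or an amine at this position would each be informative.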